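This account rests on a few compounds, and the source may have more. Where it says the series, first, only, none or still open, it means among the compounds named here.

Measured in a functional assay on A549 cells (Homo sapiens) for inhibition, read by sulforhodamine B assay, with a stated time of 48 h; on this read-out higher numbers stand for weaker inhibition and lower numbers for stronger inhibition:

- Compound 1 `O=C(Nc1ccc2c(c1)CCN2c1ccc(C(=O)NO)cc1)Nc1ccc(Cl)c(C(F)(F)F)c1`: 3400 nM
- Compound 2 `O=C(CCCCCC(=O)Nc1ccc(NC(=O)Nc2ccc(Cl)c(C(F)(F)F)c2)cc1)NO`: > 10000 nM
- Compound 3 `O=C(/C=C/c1ccc(CN2CCc3cc(NC(=O)Nc4ccc(Cl)c(C(F)(F)F)c4)ccc32)cc1)NO`: 2700 nM

The entry for compound 2, > 10000 nM, is a limit of the assay and not a number. That leaves two compounds with actual numbers: compound 3 at 2700 nM and compound 1 at 3400 nM. These two values lie within the scatter of each other, so neither can be ranked over the other.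

Compound 4 `O=C(Nc1ccc2c(c1)CCN2Cc1ccc(C(=O)NO)cc1)Nc1ccc(Cl)c(C(F)(F)F)c1` has not yet been measured. It differs from compound 3 at one place, on an aromatic carbon of a six-membered aromatic ring of carbon only, para to a large group. There, hydroxycarbamoyl stands in place of 2-(hydroxycarbamoyl)ethenyl (hydroxycarbamoyl in place of 2-(hydroxycarbamoyl)ethenyl on an aromatic carbon).

Within the data shown here, no measured pair here shows this change directly, so any forecast is loose. The expected result is a small move towards a higher number, meaning somewhat weaker inhibition, and it may not exceed the scatter. In numbers, the estimated step is a 1.5-fold higher number from compound 3 to compound 4 (0.17 log units; within the scatter).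

For compound 4, the estimated value is 4000 nM, with an expected range of 1500 nM to 10000 nM.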

Compound 4, half-maximal inhibitory concentration: 3100 nM
Beside the measured number, compound 4's estimate is 1.3-fold (0.11 log units) above it; measured number inside the range.
By their numbers in this assay, from the lowest: compounds 3, 4 and 1 (each within the scatter of the next). At a limit, above all of these: compound 2.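

At this aromatic carbon, para to a large group, hydroxycarbamoyl in place of 2-(hydroxycarbamoyl)ethenyl gives a 1.1-fold higher number from compound 3 to compound 4 (0.06 log units; within the scatter) in this assay, so shortening this group leaves no readable mark on the number. The other change, 4-(hydroxycarbamoyl)benzyl in place of 4-(hydroxycarbamoyl)phenyl on the ring nitrogen, gives a 1.1-fold lower number from compound 1 to compound 4 (0.04 log units; within the scatter) and is equally unreadable, so the three compounds with actual numbers cannot be ranked. Nothing known here bears on why either change leaves the number within the scatter.

Still open, going by these compounds, is whether a carboxylic acid in place of hydroxycarbamoyl at this aromatic carbon, or a longer chain carrying hydroxycarbamoyl there, would move the number beyond the scatter. The same question stands for a longer chain on the ring nitrogen.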